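Chloro for Methoxy on the Aryl Ring, Outcome Pending

The source may report more compounds than this note shows. Statements on the series, on what has been measured and on what is new or still open speak of the compounds shown alone.

Compound 1 `COc1cccc(N2CCN(C(=O)C(C)N3C(=O)CCC3=O)CC2)c1` — 0%
Compound 2 `CCC(C(=O)N1CCN(c2cccc(OC)c2)CC1)N1C(=O)CCC1=O` — 0%

In a functional assay on the whole organism (strain Swiss) with Mus musculus as the target, in the maximal electroshock model, with a stated time of 2 h, at a dose of 300 mg/kg by the intraperitoneal route (on this read-out higher numbers stand for a stronger effect at the one dose given and lower numbers for a weaker effect), compound 1 gives 0%, and compound 2 gives 0%. The step of no change at the digits printed from compound 1 to compound 2 (within the scatter) shows that adding the methyl on the chain left the read-out unchanged, so compound 2 stands level with compound 1. Compound 3 `CCC(C(=O)N1CCN(c2cccc(Cl)c2)CC1)N1C(=O)CCC1=O` differs from compound 2 by chloro in place of methoxy on an aromatic carbon. Going by the values given here, no measured step touches the aromatic ring, so nothing here bears directly on this change. Compound 3 is therefore expected to stay near compound 2, with the step of no change at the digits printed from compound 2 to compound 3 (within the scatter) judged within the scatter. Compound 3 is estimated at 0%, in a range from 0% to 33%.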

Compound 3, a percentage reported as activity, at one dose (the size of the read-out at that dose, not a potency): 25%
The estimate for compound 3 lay 25 percentage points below the measured number; the measured number falls inside the stated range.
By their numbers in this assay, from the lowest: compounds 1 and 2 (each within the scatter of the next); then compound 3.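

In this assay, going by these compounds alone, the change from 3-methoxyphenyl to 3-chlorophenyl gives a number 25 percentage points higher from compound 2 to compound 3 (beyond the scatter) and is the first step here to move the read-out beyond the scatter. The aromatic carbon meta to a large group is thus a place where the read-out at this one dose responds to the group carried, which the earlier chain change had not shown. Nothing given here accounts for the rise. From the compounds shown here alone, whether a bromo, a methyl or a trifluoromethyl at this place would do the same remains open. So does whether chloro would give a similar step on the chain of compound 1.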